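Carbonyl back on the nitrogen: expecting a large recovery

The source may report more compounds than this note shows. Statements on the series, on what has been measured and on what is new or still open speak of the compounds shown alone.

In a functional assay on TSGH 9201 cells (Homo sapiens) for cytotoxicity (a higher number here means a weaker inhibitor, a lower number a stronger inhibitor), compound 1 `COc1ccc(S(=O)(=O)N2CCc3cccc(NC(=O)c4ccncc4)c32)cc1` gives 10.8 nM. Compound 2 `COc1ccc(S(=O)(=O)N2CCc3cccc(NCc4ccccc4)c32)cc1` stands at > 10000 nM, which is a limit of the assay and not a number, as the limit of > 10000 nM in this assay, at which 1 of the 2 values shown sits, records. Compound 3 `COc1ccc(S(=O)(=O)N2CCc3cccc(NC(=O)c4ccco4)c32)cc1` differs from it by (furan-2-yl)carbonyl in place of benzyl on a nitrogen on an aromatic ring, with (furan-2-yl)carbonyl in place of benzyl on a nitrogen on an aromatic ring. Among the compounds with values here, the only measured step bearing on this is large: an at least 920-fold higher number from compound 1 to compound 2 (2.96 log units; beyond the scatter), where benzyl replaced (pyridin-4-yl)carbonyl. A large fall in the number is therefore expected in this assay, although no (furan-2-yl)carbonyl has been measured yet. The estimated step is an at least 250-fold lower number from compound 2 to compound 3 (2.39 log units; beyond the scatter). The estimate for compound 3 is 40 nM, with an expected range of 8 nM to 300 nM.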

Compound 3, half-maximal inhibitory concentration: 11.1 nM
Compound 3: middle estimate off by 3.6-fold (0.56 log units), on the high side; the range from low to high includes it.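

Putting (furan-2-yl)carbonyl on the nitrogen in place of benzyl gives an at least 900-fold lower number from compound 2 to compound 3 (2.95 log units; beyond the scatter), so the recovery at this position does not depend on (pyridin-4-yl)carbonyl alone. Changing the ring on the carbonyl carbon gives a 1.0-fold higher number from compound 1 to compound 3 (0.01 log units; within the scatter), so furan-2-yl and pyridin-4-yl cannot be told apart here. Compound 2 stands at a limit of the assay, so the step from it is only a bound: the limit of > 10000 nM in this assay, at which 1 of the 3 values shown sits.

Going by these compounds, it remains open whether the carbonyl or the ring type accounts for the gap. A benzoyl group on the same nitrogen would separate the two, and an acetyl group would show whether a ring on the carbonyl is needed at all.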